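Changing the Amine Substituent on a Shared Core

The compounds below may be only part of what the source reports. "The series", "measured", "known", "first", "only" and "open" are said of these compounds alone.

Measured so far:
Compound 1, `CN(CC(C)(C)C)CC1(O)CCN(CCCc2c[nH]c3ccc(-n4cnnc4)cc23)CC1`: 61 nM
Compound 2, `Cc1ccccc1CNCC1(O)CCN(CCCc2c[nH]c3ccc(-n4cnnc4)cc23)CC1`: 83 nM
Compound 3, `CN(Cc1ccccc1)CC1(O)CCN(CCCc2c[nH]c3ccc(-n4cnnc4)cc23)CC1`: 96 nM

All three were tested in an assay on CHO cells with 5-hydroxytryptamine receptor 1B (Homo sapiens) as the target; on this read-out lower numbers stand for stronger inhibition and higher numbers for weaker inhibition. Compound 3 stands highest of the three numbers, but only just: its nearest neighbour is compound 2, with a 1.2-fold higher number from compound 2 to compound 3 (0.06 log units; within the scatter), and its furthest is compound 1, with a 1.6-fold higher number from compound 1 to compound 3 (0.20 log units; within the scatter). Neither gap reaches beyond the scatter, so the three compounds cannot be placed in any order.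

Compound 4, `CC(=O)Nc1ccc(CNCC2(O)CCN(CCCc3c[nH]c4ccc(-n5cnnc5)cc34)CC2)cc1`, has not yet been measured. It differs from compound 3 in one place: (4-acetamidobenzyl)amino in place of benzyl(methyl)amino on a saturated chain carbon bound to a saturated ring carbon.

The steps already seen all concern the same position. Replacing methyl(neopentyl)amino by (2-methylbenzyl)amino gave a 1.4-fold higher number from compound 1 to compound 2 (0.13 log units; within the scatter), and replacing (2-methylbenzyl)amino by benzyl(methyl)amino gave a 1.2-fold higher number from compound 2 to compound 3 (0.06 log units; within the scatter). For the measured compounds named here, every change at this position so far has stayed within the scatter, although none of them introduced a group carrying an acetamido substituent, so the present change goes somewhat further than what has been tried. On this evidence compound 4 is expected to show no step beyond the scatter in this assay, with a 1.1-fold lower number from compound 3 to compound 4 (0.03 log units; within the scatter) as the expected change. The estimate for compound 4 is 90 nM, with a range from 40 nM to 220 nM.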

Compound 4, half-maximal inhibitory concentration: 30 nM
The estimate for compound 4 lay 3.0-fold (0.48 log units) above the measured number; measured number below the stated range.
By their numbers in this assay, from the lowest: compound 4; then compounds 1, 2 and 3 (each within the scatter of the next).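

For the compounds shown here, at the position on a saturated chain carbon bound to a saturated ring carbon, (4-acetamidobenzyl)amino is the first group to produce steps beyond the scatter in this assay: a 3.2-fold lower number from compound 3 to compound 4 (0.51 log units; beyond the scatter), a 2.8-fold lower number from compound 2 to compound 4 (0.44 log units; beyond the scatter) and a 2.0-fold lower number from compound 1 to compound 4 (0.31 log units; beyond the scatter). The position therefore responds to change after all, and compound 4 is the strongest of the four, although methyl(neopentyl)amino, (2-methylbenzyl)amino and benzyl(methyl)amino could not be told apart. Compound 2 already carries the same hydrogen on the amine nitrogen, so the absence of the methyl group found in compound 3 cannot alone account for the result, and the step from compound 2 replaces 2-methylphenyl with 4-acetamidophenyl; no measurement at hand explains why this change lowers the number.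

The compounds shown leave open whether the acetamido group itself matters, since a benzyl group carrying a free amine or a methanesulfonamide in its place would be needed to separate it from other substituents. They also leave open how the methylated amine, methyl(4-acetamidobenzyl)amino, would compare with compound 4.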